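Replacing a hydrazine group with an allylsulfanyl chain

The compounds below may be only part of what the source reports. "The series", "measured", "known", "first", "only" and "open" are said of these compounds alone.

Measured compounds:
compound 1 `Cc1ccc(-c2nc(NN)c3cc(Cl)ccc3n2)cc1` — 3.76 ug/mL
compound 2 `Cc1ccc(-c2nc(NOC(=O)c3ccccc3)c3cc(Cl)ccc3n2)cc1` — 5.59 ug/mL

In a functional assay on MCF7 cells (Homo sapiens) for antiproliferative activity, read by MTT assay, with a stated time of 48 h (on this read-out lower numbers stand for stronger inhibition and higher numbers for weaker inhibition), compound 1 gives 3.76 ug/mL, and compound 2 gives 5.59 ug/mL. Among the compounds with values here, compound 1 stands at one end of these two numbers, but its only neighbour is compound 2, and the step of a 1.5-fold higher number from compound 1 to compound 2 (0.17 log units; within the scatter) is within the scatter, so the two cannot be told apart.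

Compound 3 `C=CCSc1nc(-c2ccc(C)cc2)nc2ccc(Cl)cc12` differs from compound 1 by allylsulfanyl in place of aminoamino on an aromatic carbon. Within the data shown here, the one measured step kept a nitrogen attached to the ring carbon and changed only what sits on that nitrogen; the change to compound 3 removes both nitrogens and puts a sulfur-linked chain in their place. Among the measured compounds shown here, no measured step therefore bears directly on it, and the single step that is known was within the scatter. With nothing pointing in either direction, no step beyond the scatter is expected, though the range must be wide. Compound 3 is expected to give about 5 ug/mL in this assay, from 1.5 ug/mL to 15 ug/mL. This estimate corresponds to an expected step of a 1.3-fold higher number from compound 1 to compound 3 (0.12 log units; within the scatter).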

Compound 3, half-maximal inhibitory concentration: 8.03 ug/mL
Estimate against measurement, compound 3: 1.6-fold (0.21 log units) below; the range from low to high includes it.
By their numbers in this assay, from the lowest: compounds 1, 2 and 3 (each within the scatter of the next, the first and the last beyond it).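

In this assay, the exchange of aminoamino for allylsulfanyl on this aromatic carbon gives a 2.1-fold higher number from compound 1 to compound 3 (0.33 log units; beyond the scatter), a modest step and the first at this position to lie beyond the scatter. The earlier step changed only what sits on the nitrogen attached to the ring, whereas this one removes both nitrogens and both of the group's hydrogen-bond donors and brings in a sulfur-linked chain with a double bond, and compound 3 still gives a measurable value of 8.03 ug/mL in this assay, so the position tolerates this change with only a modest rise in the number. Nothing available explains why the number rises.

The compounds shown cannot separate the loss of the nitrogens from the arrival of the sulfur or of the allyl chain, since all of these changes occur in a single step. Still open, from the compounds shown here alone, is how the number would respond at this carbon to a methylsulfanyl group, a saturated propylsulfanyl chain, an allyloxy group with oxygen as the link, or an allylamino group that keeps a nitrogen there.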